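The source may hold more compounds than are shown below. What is called first, only, known or untested is meant among the compounds shown, and "the series" means these compounds.

Series notes. Compound 1 `O=C(Nc1ccc(Cl)cc1)C1CCCN(C(=O)c2cccc(-c3nccs3)c2)C1` gives 32% in an ADME assay on PC-3 cells (Homo sapiens) for cytotoxicity, read by WST assay, tested at 100 uM (on this read-out lower numbers stand for less inhibition and higher numbers for more inhibition at the one concentration tested (going by the name of the read-out)), and stands highest of the three measured numbers: compound 2 `CCc1cccc(NC(=O)C2CCCN(C(=O)c3cc(C(F)(F)F)cc(C(F)(F)F)c3)C2)c1` gives 0% and compound 3 `COC(=O)c1cccc(NC(=O)C2CCCN(C(=O)c3cc(C(F)(F)F)cc(C(F)(F)F)c3)C2)c1` gives 0%, both gaps beyond the scatter. For the measured compounds named here, the only measured step, no change at the digits printed from compound 2 to compound 3 (within the scatter), concerns a different exchange, methoxycarbonyl in place of ethyl, and so does not bear directly on the change followed here. Compound 4 `N#Cc1cccc(C(=O)N2CCCC(C(=O)Nc3ccc(Cl)cc3)C2)c1` differs from compound 1 by cyano in place of 1,3-thiazol-2-yl on an aromatic carbon. Going by the values given here, no measured step covers this exchange, so the expectation rests on compound 1 alone. The expected step is a number 14 percentage points lower from compound 1 to compound 4 (beyond the scatter), a drift towards the low numbers of the series rather than a change clearly beyond the scatter. Compound 4 is therefore estimated at 18%, within 0% to 40%.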

Compound 4, a percentage reported as inhibition, at one concentration (the size of the read-out at that concentration, not a potency): 0%
Compound 4: middle estimate off by 18 percentage points, on the high side, within the range that was stated.
By their numbers in this assay, from the lowest: compounds 2, 3 and 4 (each within the scatter of the next); then compound 1.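

In this assay, for the compounds shown here, cyano in place of 1,3-thiazol-2-yl on this aromatic carbon, meta to a large group, gives a number 32 percentage points lower from compound 1 to compound 4 (beyond the scatter), the only measured step at this position. The inhibition of compound 1 therefore does not survive this exchange, so the group on this carbon matters to the read-out. Nothing at hand accounts for the size of the step.

From the compounds shown here alone, whether a phenyl ring, an amine or another five-membered aromatic ring on this carbon would retain the inhibition of compound 1 remains open. So does whether the step would hold with a group other than the one carried by compound 1 elsewhere on the core.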